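Halogen swap on the lactam ring of trimethoxystyryl amides

The source may hold more compounds than are shown below. What is called first, only, known or untested is meant among the compounds shown, and "the series" means these compounds.

Compounds measured so far in a functional assay on MDA-MB-231 cells (Homo sapiens) for cytotoxicity, read by MTT assay, with a stated time of 72 h; on this read-out lower numbers stand for stronger inhibition and higher numbers for weaker inhibition:
Compound 1, `CCCC/C(=C\c1cc(OC)c(OC)c(OC)c1)C(=O)N1CCC=C(Cl)C1=O`: 6550 nM
Compound 2, `CCCC/C(=C\c1cc(OC)c(OC)c(OC)c1)C(=O)N1CCC=C(Br)C1=O`: 2440 nM
Compound 3, `CC/C(=C\c1cc(OC)c(OC)c(OC)c1)C(=O)N1CCC=C(Cl)C1=O`: 7270 nM

Compound 4, `CC/C(=C\c1cc(OC)c(OC)c(OC)c1)C(=O)N1CCC=C(Br)C1=O`, has not yet been measured in this assay. It differs from compound 3 by bromo in place of chloro on a double-bonded ring carbon. Exactly the same change has already been made once, from compound 1 to compound 2: bromo in place of chloro on a double-bonded ring carbon. That step gave a 2.7-fold lower number from compound 1 to compound 2 (0.43 log units; beyond the scatter).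

The cores of compound 1 and compound 3 differ by hydrogen in place of ethyl on a saturated chain carbon, two bonds along the chain from a double-bonded chain carbon. Between these two cores the number hardly moves: a 1.1-fold higher number from compound 1 to compound 3 (0.05 log units; within the scatter). So the shortened chain of compound 3 has not, on its own, shifted the read-out in this assay.

With the place of the halogen swap the same word for word in both pairs, and the two cores standing within the scatter of each other, the same kind of step is expected from compound 3 to compound 4, roughly a 2.7-fold lower number from compound 3 to compound 4 (0.43 log units; beyond the scatter), because the earlier swap gave a 2.7-fold lower number from compound 1 to compound 2 (0.43 log units; beyond the scatter) on a core that reads like compound 3. Compound 4 is therefore estimated at 2700 nM in this assay, with a range from 1400 nM to 5400 nM, resting on a single precedent only.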

Compound 4, half-maximal inhibitory concentration: 2120 nM
Compound 4: middle estimate off by 1.3-fold (0.11 log units), on the high side; the measured number falls inside the stated range.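

In this assay, bromo in place of chloro gives a 3.4-fold lower number from compound 3 to compound 4 (0.54 log units; beyond the scatter), and this agrees with the earlier swap on the other core: the same change on two cores in this assay, a 2.7-fold lower number (0.43 log units; beyond the scatter) from compound 1 to compound 2 and a 3.4-fold lower number (0.54 log units; beyond the scatter) from compound 3 to compound 4, 1.3-fold (0.11 log units) apart, within the scatter of two such steps The chain difference between the two bromo compounds amounts to a 1.2-fold lower number from compound 2 to compound 4 (0.06 log units; within the scatter), and the two chloro compounds read alike: the same change on two cores in this assay, a 1.1-fold higher number (0.05 log units; within the scatter) from compound 1 to compound 3 and a 1.2-fold lower number (0.06 log units; within the scatter) from compound 2 to compound 4, 1.3-fold (0.11 log units) apart, within the scatter of two such steps Together these four compounds show that the halogen swap and the chain difference carried over unchanged between these two closely related cores in this one cell assay, but they do not show that the swap would carry to a core that differs elsewhere, nor why bromo gives the lower number.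

The compounds shown leave open whether fluoro or iodo on the same double-bonded ring carbon would extend the halogen step. They also leave open whether that step would hold on a core with a longer chain, or with a hydroxyl group or an amine in place of a methoxy group on the aromatic ring.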